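The source may report more compounds than this note shows. Statements on the series, on what has been measured and on what is new or still open speak of the compounds shown alone.

For the measured compounds named here, in a functional assay on L1210 cells (Mus musculus) for inhibition, read by MTT assay, with a stated time of 72 h (a lower number here means a stronger inhibitor, a higher number a weaker inhibitor), compound 1 `COc1cc(NC(C)CCCNC(=O)NNC(=O)Nc2ccc(F)cc2)c2ncccc2c1` gives 104000 nM and compound 2 `COc1cc(NC(C)CCCNC(=O)Nc2ccc(C(F)(F)F)cc2)c2ncccc2c1` gives 7400 nM, the lower of the two numbers measured so far. Compound 3 `COc1cc(NC(C)CCCNC(=O)Nc2ccc(Cl)cc2)c2ncccc2c1` departs from compound 2 in a single substituent: chloro in place of trifluoromethyl on an aromatic carbon. In other words, the 4-(trifluoromethyl)phenyl of compound 2 becomes 4-chlorophenyl in compound 3. Going by the values given here, only one measured step is available, a 14-fold lower number from compound 1 to compound 2 (1.15 log units; beyond the scatter). That step is large, but it exchanges a much bigger portion of the structure at a different place, so it bears on the present change only indirectly. Among the compounds with values here, no measured pair tests this exchange directly. The expected change is therefore small, and the estimated step is a 1.2-fold higher number from compound 2 to compound 3 (0.09 log units; within the scatter), with no clear shift beyond the scatter in either direction. For compound 3 the expected value in this assay is 9000 nM, with an estimated range from 4000 nM to 20000 nM.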

Compound 3, half-maximal inhibitory concentration: 19000 nM
Compound 3: the middle estimate sits 2.1-fold (0.32 log units) below what was measured, and the stated range covers the measured number.
By their numbers in this assay, from the lowest: compound 2; then compound 3; then compound 1.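

In this assay, for the compounds shown here, the group on the aromatic carbon para to a large group proves to matter: chloro in place of trifluoromethyl gives a 2.6-fold higher number from compound 2 to compound 3 (0.41 log units; beyond the scatter), the first direct reading at this place and one that lies beyond the scatter. Replacing the ((4-fluorophenyl)carbamoyl)amino group on the amide-type nitrogen with 4-chlorophenyl gives a 5.5-fold lower number from compound 1 to compound 3 (0.74 log units; beyond the scatter), so the lower number seen with 4-(trifluoromethyl)phenyl also appears with a second aryl group, though trifluoromethyl retains the lowest value. No measurement available here accounts for the difference between chloro and trifluoromethyl.

As far as these compounds go, with only these two groups compared at this place, it remains open whether a nitrile, a methoxy group or a plain hydrogen would fall near compound 2, near compound 3 or outside both. From the compounds shown here alone, how an amine or a carboxylic acid at the same carbon would read also remains open.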